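The source may hold more compounds than are shown below. What is called first, only, known or untested is meant among the compounds shown, and "the series" means these compounds.

Measured in a functional assay on M4E cells (Homo sapiens) for cytotoxicity, read by resazurin assay, with a stated time of 72 h; a higher number here means a weaker inhibitor, a lower number a stronger inhibitor:
- compound 1 `COc1cc(/C=C/C(=O)OCCCCCO[N+](=O)[O-])ccc1O`: 21800 nM
- compound 2 `O=C(/C=C/c1ccc(O)c(O)c1)OCc1c(-c2ccccc2)no[n+]1[O-]`: 12900 nM

With only these two numbers available, compound 2 at 12900 nM and compound 1 at 21800 nM lie within the usual scatter of each other, so they cannot be ranked. Compound 3 `COc1cc(/C=C/C(=O)OCc2c(-c3ccccc3)no[n+]2[O-])ccc1O` is not yet measured. It differs from compound 2 by methyl in place of hydrogen on an oxygen on an aromatic ring, with methyl in place of hydrogen on an oxygen on an aromatic ring, which turns 3,4-dihydroxyphenyl into 4-hydroxy-3-methoxyphenyl. Within the data shown here, no measured pair shows this change directly. Compound 1 also carries 4-hydroxy-3-methoxyphenyl and gives 21800 nM, so only a small rise in the number is expected in this assay, none beyond the scatter. The estimated change is a 1.4-fold higher number from compound 2 to compound 3 (0.14 log units; within the scatter). For compound 3 the expected value is 18000 nM, with an estimated range of 7000 nM to 45000 nM.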

Compound 3, half-maximal inhibitory concentration: 3370 nM
Compound 3: middle estimate off by 5.3-fold (0.73 log units), on the high side; the whole stated range lies above it.
By their numbers in this assay, from the lowest: compound 3; then compounds 2 and 1 (each within the scatter of the next).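

In this assay, methyl in place of hydrogen on an oxygen on an aromatic ring, which turns 3,4-dihydroxyphenyl into 4-hydroxy-3-methoxyphenyl, gives a clear shift (a 3.8-fold lower number from compound 2 to compound 3 (0.58 log units; beyond the scatter)). Among these compounds, this is the first step that lies beyond the scatter, so this position does respond: with the rest of the structure unchanged, going from hydroxy to methoxy lowers the number. No measurement on these compounds accounts for the step.

From the compounds shown here alone, it remains open whether ethoxy or a longer chain on this oxygen would lower the number further or reverse the step. Among the compounds shown here, it is also open whether hydroxy to methoxy gives a similar step when the side chain of compound 1 replaces the one shared by compound 2 and compound 3.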